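Pyridin-4-yl in place of 3,4-dimethylphenyl: estimating cytotoxicity

The compounds below may be only part of what the source reports. "The series", "measured", "known", "first", "only" and "open" are said of these compounds alone.

- compound 1 `O[C@@H](c1ccccc1)[C@H]1CO[C@H](c2ccccc2)[C@@H](C/C=C/c2ccccc2)C1`: 7040 nM
- compound 2 `Oc1ccc(/C=C/C[C@H]2C[C@@H]([C@@H](O)c3ccccc3)CO[C@@H]2c2ccccc2)cc1`: 7380 nM
- compound 3 `Cc1ccc(/C=C/C[C@H]2C[C@@H]([C@@H](O)c3ccccc3)CO[C@@H]2c2ccccc2)cc1C`: 9880 nM

These three compounds were tested in a functional assay on HL-60 cells (Homo sapiens) for cytotoxicity, read by WST assay, with a stated time of 48 h; a lower number here means a stronger inhibitor, a higher number a weaker inhibitor. Compound 3 stands level with the other two, and neither step leading to it goes beyond the scatter: a 1.4-fold higher number from compound 1 to compound 3 (0.15 log units; within the scatter) and a 1.3-fold higher number from compound 2 to compound 3 (0.13 log units; within the scatter).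

The next compound is compound 4 `O[C@@H](c1ccccc1)[C@H]1CO[C@H](c2ccccc2)[C@@H](C/C=C/c2ccncc2)C1`. It carries pyridin-4-yl in place of 3,4-dimethylphenyl on a double-bonded chain carbon bound to a double-bonded chain carbon.

All three measured steps concern the aromatic group at this same place. The third, with hydroxy in place of hydrogen on an aromatic carbon, is a 1.0-fold higher number from compound 1 to compound 2 (0.02 log units; within the scatter). All three are small, so no step beyond the scatter is expected in this assay. Among the compounds with values here, still, no measured compound has a hetero atom in this ring, so the new change is untested and the range stays wide.

The estimated step is a 1.2-fold lower number from compound 3 to compound 4 (0.09 log units; within the scatter).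

For compound 4 the expected value is 8000 nM.

The expected range for compound 4 runs from 4000 nM to 16000 nM.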

Compound 4, half-maximal inhibitory concentration: > 100000 nM
Compound 4 gave a limit, no number; the forecaster's own chance of this, stated with the estimate: 10%; middle value at least 12-fold (1.09 log units) from the limit.
By their numbers in this assay, from the lowest: compounds 1, 2 and 3 (each within the scatter of the next). At a limit, above all of these: compound 4.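

In this assay, the aromatic group on the double-bonded chain carbon looked open to change until pyridin-4-yl entered, with an at least 10-fold higher number from compound 3 to compound 4 (1.00 log units; beyond the scatter), an at least 13-fold higher number from compound 2 to compound 4 (1.13 log units; beyond the scatter) and an at least 14-fold higher number from compound 1 to compound 4 (1.15 log units; beyond the scatter). Phenyl, 4-hydroxyphenyl and 3,4-dimethylphenyl all stand within the scatter of one another, so a hydroxy group or two methyl groups on this ring leave the number in place, while the one ring here with a nitrogen atom gives a far weaker result. The result for compound 4 is a limit, not a number: the limit of > 100000 nM in this assay, at which 1 of the 4 values shown sits.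

A single compound cannot show whether this sharp drop belongs to the ring nitrogen in general or to pyridin-4-yl alone. A pyrimidine ring or an aminophenyl group at this place would help to separate the two.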